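From dichlorophenyl to trifluorophenyl in a barely active set

The source may hold more compounds than are shown below. What is called first, only, known or untested is meant among the compounds shown, and "the series" means these compounds.

In a functional assay on G-361 cells (Homo sapiens) for antiproliferative activity, with a stated time of 72 h (a lower number here means a stronger inhibitor, a higher number a weaker inhibitor), compound 1 (`OC[C@H]1O[C@@H](n2cnc3c(NCc4cccc(F)c4)ncnc32)[C@H](O)[C@@H]1O`) gives > 166000 nM, which is a limit and not a number. Compound 2 (`OC[C@H]1O[C@@H](n2cnc3c(NCc4ccc(F)cc4)ncnc32)[C@H](O)[C@@H]1O`) gives > 166000 nM, again a limit. Within the data shown here, compound 3 (`OC[C@H]1O[C@@H](n2cnc3c(NCc4ccc(Cl)c(Cl)c4)ncnc32)[C@H](O)[C@@H]1O`) gives 145000 nM, the only true number among the three.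

Compound 4 (`OC[C@H]1O[C@@H](n2cnc3c(NCc4ccc(F)c(F)c4F)ncnc32)[C@H](O)[C@@H]1O`) carries 2,3,4-trifluorophenyl in place of 3,4-dichlorophenyl on a saturated chain carbon bound to a nitrogen on an aromatic ring.

Among the measured compounds shown here, two measured steps bear on this change: an at least 1.1-fold lower number from compound 1 to compound 3 (0.05 log units; that floor lies within the scatter) and an at least 1.1-fold lower number from compound 2 to compound 3 (0.05 log units; that floor lies within the scatter). Both are the reverse kind of swap, from a fluorine-bearing group to 3,4-dichlorophenyl, and their floors are small, so no step beyond the scatter is expected in this assay. The nearest guide is the limit of > 166000 nM in this assay, at which 2 of the 3 values shown sit, so a limit is a real possibility for the new result.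

The expected change is a 1.1-fold higher number from compound 3 to compound 4 (0.04 log units; within the scatter). For compound 4 the estimated value is 160000 nM, with an expected range of 90000 nM to 280000 nM.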

Compound 4, half-maximal inhibitory concentration: > 166000 nM
Compound 4: no number, only a limit; the forecaster's own chance of this, stated with the estimate: 60%; at least 1.0-fold (0.01 log units) between middle value and limit.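

In this assay compound 4 returns only a limit, so 2,3,4-trifluorophenyl sits with 3-fluorophenyl and 4-fluorophenyl and adds no second true number at this position, on a saturated chain carbon bound to a nitrogen on an aromatic ring. The one readable step is an at least 1.1-fold higher number from compound 3 to compound 4 (0.05 log units; that floor lies within the scatter), so this swap is not shown to change anything beyond the scatter, and the steps from compound 1 and compound 2 to compound 4 cannot be read. Compound 3 remains the only compound with a true number, and limits dominate the set: the limit of > 166000 nM in this assay, at which 3 of the 4 values shown sit.

Still open, as far as these compounds go, is whether a phenyl ring carrying methoxy or trifluoromethyl, or a longer chain in place of the single chain carbon, would give a number clearly lower than that of compound 3. Also open, from the compounds shown here alone, is whether a single chlorine on the phenyl ring would give a true number at all.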